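Working notes on the shared core: a chain substituent test

The source may hold more compounds than are shown below. What is called first, only, known or untested is meant among the compounds shown, and "the series" means these compounds.

The series is read in an assay on isolated protein for inhibition of N-lysine methyltransferase SMYD2 (Homo sapiens), read by filter binding, with a stated time of 1 h; a lower number here means a stronger inhibitor, a higher number a weaker inhibitor. Compound 1 `CC1COC2(C=CC(=O)C=C2)N(C(C)C)C1=O` returns only a limit in this assay, > 20000 nM, and no number. Compound 2 `C=CCC1COC2(C=CC(=O)C=C2)N(C(C)C)C1=O` likewise returns only a limit, > 20000 nM. For the measured compounds named here, the one measured step, a step that the two limits leave unreadable from compound 1 to compound 2, is therefore unreadable, and it is the only step touching the saturated chain carbon bound to a saturated ring carbon. What the measured values show is summed up in the limit of > 20000 nM in this assay, at which 2 of the 2 values shown sit.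

Compound 3 `CC(C)N1C(=O)C(Cc2ccc(C#N)cc2)COC12C=CC(=O)C=C2` differs from compound 1 by 4-cyanophenyl in place of hydrogen on a saturated chain carbon bound to a saturated ring carbon. Going by the values given here, the single measured step at this place carries no readable size, so nothing measured gives a direction or a size for this change. Both measured values sit at the limit, and nothing among them points toward a stronger inhibitor. Compound 3 is accordingly expected to remain at or near the limit, the expected step being a step that the limit leaves unreadable from compound 1 to compound 3, with the real chance that this assay again reports only a limit. The estimate for compound 3 in this assay is 25000 nM, within a range of 4000 nM to 150000 nM.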

Compound 3, half-maximal inhibitory concentration: > 20000 nM
Compound 3 gave a limit, no number; the forecaster's own chance of this, stated with the estimate: 70%; the middle value does not contradict the limit.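

In this assay compound 3 gives > 20000 nM, a limit and not a number. No new step can be read among compound 1, compound 2 and compound 3, and the series stands at one limit: the limit of > 20000 nM in this assay, at which 3 of the 3 values shown sit.

The compounds shown leave open whether any substituent at this place on the shared core gives a measurable value.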